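Methyl for hydrogen on the fused ring: compound 4

A few compounds are considered here, and "the series" means these few. Any claim that something is new, unique, unknown or untested is made for them only; others in the source may bear on it.

compound 1, `Cc1ccc2nc(Nc3ccnc(Nc4ccc(S(C)(=O)=O)cc4)n3)sc2c1`: > 50000 nM
compound 2, `COc1ccc2nc(Nc3ccnc(Nc4ccc(S(N)(=O)=O)cc4)n3)sc2c1`: 11000 nM
compound 3, `NS(=O)(=O)c1ccc(Nc2nccc(Nc3nc4ccccc4s3)n2)cc1`: 15300 nM

In a functional assay on MCF7 cells (Homo sapiens) for antiproliferative activity, read by MTT assay, with a stated time of 48 h (on this read-out lower numbers stand for stronger inhibition and higher numbers for weaker inhibition), compound 3 gives 15300 nM, the higher of the two numbers; nearest stands compound 2 with 11000 nM. Going by the values given here, the one measured step, a 1.4-fold higher number from compound 2 to compound 3 (0.14 log units; within the scatter), is within the scatter. The value of compound 1 is a limit of the assay, (the limit of > 50000 nM in this assay, at which 1 of the 3 values shown sits).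

Compound 4, `Cc1ccc2nc(Nc3ccnc(Nc4ccc(S(N)(=O)=O)cc4)n3)sc2c1`, differs from compound 3 by methyl in place of hydrogen on an aromatic carbon. Among the compounds with values here, no measured step alters this group directly; the only step, a 1.4-fold higher number from compound 2 to compound 3 (0.14 log units; within the scatter), changed a group on the same ring and stayed within the scatter. Compound 1 also carries the methyl, with a different partner group, and gives only a limit.

Compound 4 is therefore expected near 15000 nM, between 6000 nM and 40000 nM. The expected step of a 1.0-fold lower number from compound 3 to compound 4 (0.01 log units; within the scatter) lies within the scatter.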

Compound 4, half-maximal inhibitory concentration: 5740 nM
Beside the measured number, compound 4's estimate is 2.6-fold (0.42 log units) above it; the measured number lies below the stated range.
By their numbers in this assay, from the lowest: compounds 4, 2 and 3 (each within the scatter of the next, the first and the last beyond it). At a limit, above all of these: compound 1.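

In this assay, going by these compounds alone, methyl gives the first step at this position that lies beyond the scatter, a 2.7-fold lower number from compound 3 to compound 4 (0.43 log units; beyond the scatter), while methyl and methoxy remain unseparated, a 1.9-fold lower number from compound 2 to compound 4 (0.28 log units; within the scatter). With methyl held in place, changing the group on the sulfonyl sulfur gives an at least 8.7-fold lower number from compound 1 to compound 4 (0.94 log units; beyond the scatter). Compound 1 stands at a limit, so that step has no exact size: the limit of > 50000 nM in this assay, at which 1 of the 4 values shown sits.

The gain from methyl rests on this single pair. From the compounds shown here alone, whether ethyl, chlorine or an amine on the same aromatic carbon would give a similar number remains open.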